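Trifluoromethoxy in place of trifluoromethyl: an estimate

The compounds below may be only part of what the source reports. "The series", "measured", "known", "first", "only" and "open" are said of these compounds alone.

Measured so far:
Compound 1 `COC(=O)c1scc(-c2ccc(NC(=O)c3ccccn3)cc2)c1OC` gives 10300 nM in a functional assay on HepG2 cells (Homo sapiens) for antiproliferative activity, read by MTT assay, with a stated time of 24 h; a lower number here means a stronger inhibitor, a higher number a weaker inhibitor.
Compound 2 `COC(=O)c1scc(-c2ccc(NC(=O)c3cccc(C(F)(F)F)c3)cc2)c1OC` gives 32500 nM in this assay.
Compound 3 `COC(=O)c1scc(-c2ccc(NC(=O)c3ccc(F)c(Cl)n3)cc2)c1OC` gives 10300 nM in this assay.

Compound 2 has the highest number of the three, so it is the weakest inhibitor measured here. Going from compound 1 to compound 2 gives a 3.2-fold higher number from compound 1 to compound 2 (0.50 log units; beyond the scatter), and going from compound 2 to compound 3 gives a 3.2-fold lower number from compound 2 to compound 3 (0.50 log units; beyond the scatter), while compound 1 and compound 3 sit within the scatter of each other no change at the digits printed from compound 1 to compound 3 (within the scatter).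

Compound 4 `COC(=O)c1scc(-c2ccc(NC(=O)c3cccc(OC(F)(F)F)c3)cc2)c1OC` differs from compound 2 in one place: trifluoromethoxy in place of trifluoromethyl on an aromatic carbon. Both measured steps exchange the whole aromatic ring on the carbonyl carbon; neither changes a single group on a six-membered aromatic ring of carbon only. They therefore give no direct guide to this change, and the expectation is a step that stays within the scatter, a 1.1-fold lower number from compound 2 to compound 4 (0.03 log units; within the scatter). Compound 4 is estimated at 30000 nM, with a range from 10000 nM to 90000 nM.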

Compound 4, half-maximal inhibitory concentration: 720 nM
Compound 4: the middle estimate sits 42-fold (1.62 log units) above what was measured; the measured number lies below the stated range.
By their numbers in this assay, from the lowest: compound 4; then compounds 1 and 3 (each within the scatter of the next); then compound 2.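

Trifluoromethoxy in place of trifluoromethyl gives a 45-fold lower number from compound 2 to compound 4 (1.65 log units; beyond the scatter) in this assay and so shows that a single group on this ring, meta to a large group, can matter greatly. The earlier steps shown here exchanged the whole ring and gave nothing larger than a 3.2-fold higher number from compound 1 to compound 2 (0.50 log units; beyond the scatter) in size, whereas this step keeps the ring and the position and adds one oxygen, counted as one hydrogen-bond acceptor. No measurement shown here explains why this exchange has so large an effect.

On these data alone, it remains open whether the oxygen link or the whole trifluoromethoxy group carries the change. An amine, a hydroxyl or a longer ether chain such as ethoxy on this ring carbon would help to separate the two.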